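Swapping Fluoro for Methyl: Estimating Compound 4

The source may report more compounds than this note shows. Statements on the series, on what has been measured and on what is new or still open speak of the compounds shown alone.

Compound 1 `CC#C[C@@H](Cc1nnn[nH]1)c1ccc(OCc2ccc3scc(-c4cncnc4C)c3c2)cc1`: 18 nM
Compound 2 `CC#C[C@@H](Cc1nnn[nH]1)c1ccc(OCc2ccc3sc(F)c(-c4ccc(OCCOC)cc4C)c3c2)cc1`: 24 nM
Compound 3 `CC#C[C@@H](Cc1nnn[nH]1)c1ccc(OCc2ccc3sc(F)c(-c4ccccc4C)c3c2)cc1`: 14 nM

All three were tested in a functional assay on cells for agonist activity at Free fatty acid receptor 1 (Rattus norvegicus), read by FLIPR and calcium flux; a higher number here means that more compound is needed for the effect, a lower number that less compound is needed. Compound 3 sits at the low end of the three numbers, yet its gaps to compound 1 and compound 2 are both within the scatter, so the three cannot be told apart. For the measured compounds named here, the one single-point comparison, a 1.7-fold lower number from compound 2 to compound 3 (0.23 log units; within the scatter), changes a 2-methoxyethoxy group elsewhere on the molecule and stays within the scatter; it says nothing about the place altered here.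

Compound 4 `CC#C[C@@H](Cc1nnn[nH]1)c1ccc(OCc2ccc3sc(C)c(-c4ccccc4C)c3c2)cc1` has not yet been measured. It differs from compound 3 by methyl in place of fluoro on an aromatic carbon. Going by the values given here, no measured step touches this fluoro, so there is no direct guide; the only hint is that every change seen so far, including the removal of a sizeable side chain, left the number essentially unmoved.

Compound 4 is therefore expected to give 16 nM, with a range from 6 nM to 45 nM. The expected step of a 1.1-fold higher number from compound 3 to compound 4 (0.06 log units; within the scatter) is thus no change beyond the scatter, with wide uncertainty.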

Compound 4, half-maximal effective concentration: 10 nM
The estimate for compound 4 lay 1.6-fold (0.20 log units) above the measured number; measured number inside the range.
By their numbers in this assay, from the lowest: compounds 4, 3, 1 and 2 (each within the scatter of the next, the first and the last beyond it).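

For the compounds shown here, this is the first measured change at the position on the five-membered aromatic ring next to the ring sulfur, and in this assay methyl in place of fluoro gives a 1.4-fold lower number from compound 3 to compound 4 (0.15 log units; within the scatter). The position therefore accepts either of these two small groups with no change that can be told from the scatter, so fluoro is not required here for a low number. No independent measurement is available to explain why the two groups read alike.

These two compounds cover only fluoro and methyl at this position, so they leave open whether something larger or quite different, such as an ethyl group, an amine or a carboxylic acid, would be accepted as well. They also cannot show whether the same swap would read alike with a different group on the shared core.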